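Swapping a Hydroxybenzyl Ether for a Hydroxycyclohexyl Ether

The source may report more compounds than this note shows. Statements on the series, on what has been measured and on what is new or still open speak of the compounds shown alone.

Compound 1 `O=S(=O)(NCCNC(=S)Nc1cc(C(F)(F)F)cc(C(F)(F)F)c1)c1ccc(-c2ccccc2OCc2cccc(O)c2)s1` and compound 2 `O=C(NCCNS(=O)(=O)c1ccc(-c2ccccc2OCc2cccc(O)c2)s1)Nc1cc(C(F)(F)F)cc(C(F)(F)F)c1` share most of their structure; the difference between the two cores is not broken down here. In an ADME assay on HEK-293T cells (Homo sapiens) for cytotoxicity, read by CCK-8 assay, with a stated time of 48 h (a lower number here means a stronger inhibitor, a higher number a weaker inhibitor), compound 1 gives only a limit of the assay, > 20000 nM. Compound 2 likewise gives only a limit, > 20000 nM. Compound 3 `O=S(=O)(NCCNC(=S)Nc1cc(C(F)(F)F)cc(C(F)(F)F)c1)c1ccc(-c2ccccc2O[C@H]2CC[C@@H](O)CC2)s1` arises from compound 1 by one change, (4-hydroxycyclohexyl in place of 3-hydroxybenzyl on an oxygen on an aromatic ring). In this assay compound 3 again gives only a limit, > 20000 nM. The step that the two limits leave unreadable from compound 1 to compound 3 therefore cannot be sized, because of the limit of > 20000 nM in this assay, at which 3 of the 3 values shown sit. Compound 4 `O=C(NCCNS(=O)(=O)c1ccc(-c2ccccc2O[C@H]2CC[C@@H](O)CC2)s1)Nc1cc(C(F)(F)F)cc(C(F)(F)F)c1` is made from compound 2 by the same change, (4-hydroxycyclohexyl in place of 3-hydroxybenzyl on an oxygen on an aromatic ring). Because the step that the two limits leave unreadable from compound 1 to compound 3 stayed unreadable, the expected step is a step that the limit leaves unreadable from compound 2 to compound 4. Compound 4 is thus expected to give about 30000 nM, most probably once more only a limit.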

Compound 4, half-maximal inhibitory concentration: 14100 nM
The estimate for compound 4 lay 2.1-fold (0.33 log units) above the measured number; measured number inside the range.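

In this assay, the swap to 4-hydroxycyclohexyl gives an at least 1.4-fold lower number from compound 2 to compound 4 (0.15 log units; that floor lies within the scatter), so compound 4 reaches a readable number, 14100 nM. Among the compounds shown here, this shows only that the change can bring a readable number on this one core; a floor of this size does not establish a real shift. The steps on the other core cannot be read, and the two cores cannot be compared, because the values stop at the assay's limit: the limit of > 20000 nM in this assay, at which 3 of the 4 values shown sit.

Going by these compounds, the true size of the change on either core remains open. On these data alone, it is also open how the number would respond if an amine or a carboxylic acid replaced the hydroxyl group on the cyclohexyl ring.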